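From Compound 2 to Compound 4: One Added Methyl

The compounds below may be only part of what the source reports. "The series", "measured", "known", "first", "only" and "open" are said of these compounds alone.

Of the compounds shown here, three sharing one core have been tested in a functional assay on MCF7 cells (Homo sapiens) for inhibition, read by sulforhodamine B assay, with a stated time of 48 h (on this read-out lower numbers stand for stronger inhibition of growth and higher numbers for weaker inhibition of growth), so far. Among the compounds with values here, compound 2 (`S=C(N/N=C/c1cccs1)Nc1ccccc1`) gives 94600 nM as the only actual number among them. Compound 1 (`S=C(N/N=C/c1cccs1)Nc1ccc(Cl)cc1`) gives > 100000 nM as a limit of the assay, not a number. Compound 3 (`S=C(N/N=C/c1cccs1)Nc1cccc2ccccc12`) gives > 100000 nM as a limit as well. The data therefore centre on the limit of > 100000 nM in this assay, at which 2 of the 3 values shown sit, as their main feature, with compound 2 the one case that yields a number.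

Compound 4 (`Cc1ccc(NC(=S)N/N=C/c2cccs2)cc1`) differs from compound 2 by a single change, methyl in place of hydrogen on an aromatic carbon, para to a large group (methyl in place of hydrogen on an aromatic carbon). Within the data shown here, only one measured step bears on this, hydrogen in place of chloro on an aromatic carbon, and it amounts to an at least 1.0-fold lower number from compound 1 to compound 2 (0.02 log units; that floor lies within the scatter) as a floor only. That step shows no size of effect for a substituent at such a place, and it gives no direction. No step beyond the scatter is therefore expected in this assay, and compound 4 may also be reported only as a limit. The expected change is a 1.1-fold lower number from compound 2 to compound 4 (0.02 log units; within the scatter) and it carries no firm direction. Compound 4 is estimated at 90000 nM with an expected range from 45000 nM to 130000 nM in this assay.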

Compound 4, concentration for 50% growth inhibition: 38600 nM
Compound 4: the middle estimate sits 2.3-fold (0.37 log units) above what was measured; measured number below the stated range.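

In this assay, within the data shown here, the methyl on this aromatic carbon, para to a large group, gives the first step at this position with a clear direction and a size beyond the scatter, with a 2.5-fold lower number from compound 2 to compound 4 (0.39 log units; beyond the scatter). Replacing chloro at the same place also gives a lower number, with an at least 2.5-fold lower number from compound 1 to compound 4 (0.41 log units; beyond the scatter), but that step is only a floor, and the value of compound 1 is a limit of the assay, not a number. The position therefore responds to a change of one heavy atom, although the step is modest and only two of the compounds shown yield actual numbers, the rest remaining at the limit: the limit of > 100000 nM in this assay, at which 2 of the 4 values shown sit.

The compounds shown leave open whether a longer chain such as ethyl or isopropyl at this place would lower the number further, or whether methoxy or an amine would give a similar step. They also leave open whether methyl on another carbon of the ring would do the same, and how large the difference between chloro and hydrogen really is.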